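The compounds below may be only part of what the source reports. "The series", "measured", "known", "first", "only" and "open" are said of these compounds alone.

Measured compounds:
- compound 1 `Cc1cn2c(/C=N/NC(=N)N)c(-c3ccncc3)nc2s1`: 17400 nM
- compound 2 `Cc1sc2nc(-c3ccncc3)c(/C=N/NC(=N)N)n2c1C`: 55000 nM

Both were tested in a functional assay on prostate cells (Homo sapiens) for antiproliferative activity; on this read-out lower numbers stand for stronger inhibition of growth and higher numbers for weaker inhibition of growth. Going by the values given here, compound 1 gives the lowest of the two numbers; compound 2 stands nearest, and the only measured step, a 3.2-fold higher number from compound 1 to compound 2 (0.50 log units; beyond the scatter), adds a methyl on an aromatic carbon of the shared core.

Compound 3 `Cc1cn2c(/C=N/NC(=N)N)c(-c3cccnc3)nc2s1` has not yet been measured. It differs from compound 1 by pyridin-3-yl in place of pyridin-4-yl on an aromatic carbon: the two contain the same atoms, joined differently, so only the position of the ring nitrogen in the attached six-membered ring moves.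

Among the compounds with values here, no measured step speaks to this kind of change. Within the data shown here, the one step on record, from compound 1 to compound 2, concerns a methyl group elsewhere on the core and therefore says nothing about swapping one pyridyl isomer for another. With nothing to lean on, the expectation is that compound 3 lands close to compound 1, without a step beyond the scatter, though the uncertainty is wide in both directions. Compound 3 is therefore estimated at 20000 nM, with a range from 6000 nM to 70000 nM, meaning an expected step of a 1.1-fold higher number from compound 1 to compound 3 (0.06 log units; within the scatter) in this assay.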

Compound 3, concentration for 50% growth inhibition: 6920 nM
Estimate against measurement, compound 3: 2.9-fold (0.46 log units) above; low and high end bracket the measured number.
By their numbers in this assay, from the lowest: compound 3; then compound 1; then compound 2.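

In this assay, moving only the ring nitrogen of the attached six-membered ring gives a 2.5-fold lower number from compound 1 to compound 3 (0.40 log units; beyond the scatter), so the read-out responds to where that nitrogen sits, even though the two groups have the same atoms and the same counts of hydrogen-bond donors and acceptors. Going by these compounds alone, the earlier step concerned only a methyl group on the shared core, whereas this one is the first to probe the group on the aromatic carbon of the five-membered ring, and it runs towards stronger inhibition of growth, not weaker. No measurement shown here explains why pyridin-3-yl gives the lower number than pyridin-4-yl.

The compounds shown leave open whether a plain phenyl ring, with no ring nitrogen at all, or a pyrimidine ring at this position would give a lower or a higher number than either pyridyl group. They also leave open whether pyridin-3-yl would bring a similar step on the core of compound 2, which carries the additional methyl group.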